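Cyclohexylamino in place of 2-hydroxyethoxy on the chain

The compounds below may be only part of what the source reports. "The series", "measured", "known", "first", "only" and "open" are said of these compounds alone.

In a functional assay on SK-OV-3 cells (Homo sapiens) for inhibition, read by CCK-8 assay, with a stated time of 70 h (on this read-out lower numbers stand for stronger inhibition and higher numbers for weaker inhibition), compound 1 (`c1ccc(COc2ccc(OCCOCCOC3CCCC3)cc2)cc1`) gives > 100000 nM as a limit and not a number. For the measured compounds named here, compound 2 (`OCCOCCOCCOc1ccc(OCc2ccccc2)cc1`) gives 59400 nM as the only true number so far. Compound 3 (`c1ccc(COc2ccc(OCCOCCNC3CCCCC3)cc2)cc1`) carries cyclohexylamino in place of 2-hydroxyethoxy on a saturated chain carbon, two bonds along the chain from an oxygen on a saturated carbon. Going by the values given here, the only measured step, an at least 1.6-fold lower number from compound 1 to compound 2 (0.22 log units; that floor lies within the scatter), rests on a limit and gives no firm guide. No step beyond the scatter is therefore expected, and the estimated change is a 2.0-fold lower number from compound 2 to compound 3 (0.30 log units; within the scatter) with wide uncertainty. For compound 3 the estimated value is 30000 nM within an expected range of 6000 nM to 90000 nM overall.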

Compound 3, half-maximal inhibitory concentration: 7370 nM
Compound 3: the middle estimate sits 4.1-fold (0.61 log units) above what was measured; low and high end bracket the measured number.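

In this assay, for the compounds shown here, this position on the chain turns out to respond: cyclohexylamino in place of 2-hydroxyethoxy gives an 8.1-fold lower number from compound 2 to compound 3 (0.91 log units; beyond the scatter), the first step beyond the scatter. Against cyclopentyloxy at the same place, the change reads an at least 13-fold lower number from compound 1 to compound 3 (1.13 log units; beyond the scatter). Compound 1 gives > 100000 nM, which is a limit, so that step is only a floor: the limit of > 100000 nM in this assay, at which 1 of the 3 values shown sits.

On these data alone, what stays open is whether the step follows the amine nitrogen or the six-membered ring. An open-chain amine such as diethylamino, or a cyclohexyl ring joined through oxygen, would separate the two.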